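A few compounds are considered here, and "the series" means these few. Any claim that something is new, unique, unknown or untested is made for them only; others in the source may bear on it.

Working notes on the series.

Compound 1 `COc1ccc(C(=O)CSc2nc(CC3CCCCC3)c(C(C)C)c(=O)[nH]2)cc1` in an ADME assay on C1866 cells (Homo sapiens) for cytotoxicity, read by MTT assay, with a stated time of 72 h (a higher number here means that more compound is needed for the effect, a lower number that less compound is needed), gives 0.162 nM. Compound 2 `CC(C)c1c(CC2CCCCC2)nc(SCC(=O)c2ccccc2)[nH]c1=O` in this assay gives 0.025 nM. Compound 3 `COc1ccc(C(=O)CSc2nc(CC3CCCCC3)c(C)c(=O)[nH]2)cc1` in this assay gives 1060 nM, the highest number of the three measured compounds. Compound 4 `Cc1c(CC2CCCCC2)nc(SCC(=O)c2ccccc2)[nH]c1=O` has not yet been measured in this assay.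

The change from compound 1 to compound 2 is hydrogen in place of methoxy on an aromatic carbon, and the step it made is a 6.5-fold lower number from compound 1 to compound 2 (0.81 log units; beyond the scatter). The two cores differ as well: compound 3 is set apart from compound 1 by methyl in place of isopropyl on an aromatic carbon, with a step of a 6500-fold higher number from compound 1 to compound 3 (3.82 log units; beyond the scatter), a large move in the other direction.

Within the data shown here, the change from compound 3 to compound 4 is hydrogen in place of methoxy on an aromatic carbon, the same change as the one from compound 1 to compound 2, made on the core of compound 3 rather than on that of compound 1.

Among the measured compounds shown here, for compound 4 the expected step is a 5.3-fold lower number from compound 3 to compound 4 (0.72 log units; beyond the scatter), set beside the measured step from compound 1 to compound 2; the expectation rests on that single earlier step, because a 6.5-fold lower number from compound 1 to compound 2 (0.81 log units; beyond the scatter) is the only measurement of this change here, and it is carried over to a core that stands far from compound 1, as a 6500-fold higher number from compound 1 to compound 3 (3.82 log units; beyond the scatter) shows. For compound 4 in this assay the estimate is 200 nM, with a likely range from 30 nM to 1500 nM.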

Compound 4, half-maximal effective concentration: 75.8 nM
The estimate for compound 4 lay 2.6-fold (0.42 log units) above the measured number; measured number inside the range.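

The change from 4-methoxyphenyl to phenyl gives a 14-fold lower number from compound 3 to compound 4 (1.15 log units; beyond the scatter) in this assay, and its size on the core of compound 3 agrees with its size on the core of compound 1: the same change on two cores in this assay, a 6.5-fold lower number (0.81 log units; beyond the scatter) from compound 1 to compound 2 and a 14-fold lower number (1.15 log units; beyond the scatter) from compound 3 to compound 4, 2.2-fold (0.33 log units) apart, within the scatter of two such steps

The change from isopropyl to methyl gives a 3000-fold higher number from compound 2 to compound 4 (3.48 log units; beyond the scatter), so this much larger step also carries from one core to the other: the same change on two cores in this assay, a 6500-fold higher number (3.82 log units; beyond the scatter) from compound 1 to compound 3 and a 3000-fold higher number (3.48 log units; beyond the scatter) from compound 2 to compound 4, 2.2-fold (0.33 log units) apart, within the scatter of two such steps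

Within the four compounds shown, each change can therefore be carried between these two cores with its size preserved within the scatter, but this rests on a single set of four compounds in one assay and does not show that either step would keep its size on any other core, nor does it explain why either step is as large as it is.

As far as these compounds go, what stays open is whether the same agreement holds for other groups in the place of the methoxy, such as a chlorine atom or an amine, and for ethyl or a longer chain in the place of the isopropyl. The compounds shown also leave open whether the two steps would still hold with a different group in the place of the cyclohexylmethyl.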